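Swapping a Side Chain on a Weak Inhibitor

A few compounds are considered here, and "the series" means these few. Any claim that something is new, unique, unknown or untested is made for them only; others in the source may bear on it.

Compound 1 `COCc1cccc2[nH]c(-c3n[nH]c4ncc(-c5cccnc5)cc34)nc12`: 19 nM
Compound 2 `CC(C)OCc1cccc2[nH]c(-c3n[nH]c4ncc(-c5cncc6ccccc56)cc34)nc12`: 2880 nM

In a functional assay on HCT-116 cells (Homo sapiens) for antiproliferative activity (on this read-out lower numbers stand for stronger inhibition and higher numbers for weaker inhibition), compound 2 gives 2880 nM, the highest of the two numbers. Compound 1 gives 19 nM in the same read-out, a gap beyond the usual scatter, and the two compounds differ in more than one place, so no single change explains it.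

Compound 3 `CCN(CC)C(=O)c1cccc2[nH]c(-c3n[nH]c4ncc(-c5cncc6ccccc56)cc34)nc12` differs from compound 2 by diethylcarbamoyl in place of isopropoxymethyl on an aromatic carbon. Going by the values given here, no measured pair isolates this change, so its effect is unknown. The expected step of a 1.4-fold lower number from compound 2 to compound 3 (0.16 log units; within the scatter) is small, with direction uncertain and no change beyond the scatter the most likely outcome. Compound 3 is therefore estimated at 2000 nM, within 300 nM to 10000 nM.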

Compound 3, half-maximal inhibitory concentration: 55 nM
Compound 3: middle estimate off by 36-fold (1.56 log units), on the high side, and the stated range ends above it.
By their numbers in this assay, from the lowest: compound 1; then compound 3; then compound 2.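

In this assay, the group on this aromatic carbon matters greatly: with the rest of compound 2 unchanged, diethylcarbamoyl in place of isopropoxymethyl gives a 52-fold lower number from compound 2 to compound 3 (1.72 log units; beyond the scatter) in a single change. Compound 1 and compound 2 could not show this, as they differ in more than one place. Nothing available here explains the size of this step. Still open, going by these compounds, is whether the diethyl part is needed, or whether dimethylcarbamoyl, a primary amide or a carboxylic acid at this place would do as well.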